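A few compounds are considered here, and "the series" means these few. Any claim that something is new, unique, unknown or untested is made for them only; others in the source may bear on it.

Going by the values given here, compound 2 `COc1cc(C2=NN(C(C)=O)C(c3ccc(F)c(F)c3)O2)cc(OC)c1OC` is one of three compounds measured in a functional assay on BGC-823 cells (Homo sapiens) for antiproliferative activity, read by MTT assay, tested at 5 uM (on this read-out lower numbers stand for a weaker effect and higher numbers for a stronger effect at the one concentration tested), together with compound 1 `COc1cc(C2=NN(C(C)=O)C(c3cccc(F)c3)O2)cc(OC)c1OC` and compound 3 `COc1cc(C(=O)N/N=C/c2ccc(C(F)(F)F)cc2)cc(OC)c1OC`. In this assay compound 3 gives 56.3%, compound 1 gives 37.7%, and compound 2 gives 21.6%, the lowest of the three numbers, with compound 1 the nearest to it and compound 3 the furthest, both gaps beyond the scatter. Among the compounds with values here, the only single-point step among the measured compounds is a number 16.1 percentage points lower from compound 1 to compound 2 (beyond the scatter), a modest fall on adding a second fluorine to the ring on the saturated ring carbon.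

Compound 4 `COc1cc(C2=NN(C(C)=O)C(c3ccccc3F)O2)cc(OC)c1OC` arises from compound 2 by the change (2-fluorophenyl in place of 3,4-difluorophenyl on a saturated ring carbon). That step bears on the fluorine count rather than its placement: compound 4 carries one fluorine like compound 1, not two like compound 2. The measured fall from compound 1 to compound 2 suggests that going back to a single fluorine may recover part of it, so a modest rise is expected, a number 10.4 percentage points higher from compound 2 to compound 4 (beyond the scatter). Compound 4 is estimated at 32%, within a range from 16% to 48%.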

Compound 4, a percentage reported as inhibition, at one concentration (the size of the read-out at that concentration, not a potency): 32.8%
Beside the measured number, compound 4's estimate is 0.8 percentage points below it; the measured number falls inside the stated range.
By their numbers in this assay, from the lowest: compound 2; then compounds 4 and 1 (each within the scatter of the next); then compound 3.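

In this assay the step is a number 11.2 percentage points higher from compound 2 to compound 4 (beyond the scatter) on exchanging 3,4-difluorophenyl for 2-fluorophenyl, so the fall seen on reaching the 3,4-difluorophenyl group is also reversed by a single fluorine at a placement other than that of compound 1. The comparison of the two single-fluorine compounds gives a number 4.9 percentage points lower from compound 1 to compound 4 (within the scatter) and so does not separate 2-fluorophenyl from 3-fluorophenyl at this saturated ring carbon on this read-out. Nothing given here explains either step.

The compounds shown leave open whether the difference from compound 2 follows the number of fluorines or their placement. They also leave open how a chlorophenyl, a methoxyphenyl or an aminophenyl group at this carbon would compare.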